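Swapping the aryl group on the triazole in a spiro series

A few compounds are considered here, and "the series" means these few. Any claim that something is new, unique, unknown or untested is made for them only; others in the source may bear on it.

Three close relatives of one shared core have been tested in a functional assay on A549 cells (Homo sapiens) for antiproliferative activity, read by MTT assay, with a stated time of 48 h; on this read-out higher numbers stand for weaker inhibition and lower numbers for stronger inhibition. Compound 1, `Cc1ccccc1-n1nncc1CN1C(=O)C2(C(C#N)=C(N)Oc3c2c2nc4ccccc4nc2c2ccccc32)c2ccccc21`, carries a 2-methylphenyl on the triazole nitrogen. In this assay compound 1 gives > 50000 nM, which is a limit of the assay rather than a number. Compound 2, `N#CC1=C(N)Oc2c(c3nc4ccccc4nc3c3ccccc23)C12C(=O)N(Cc1cnnn1-c1ccc(F)cc1)c1ccccc12`, carries a 4-fluorophenyl instead. In this assay compound 2 gives > 50000 nM, again a limit and not a number. Within the data shown here, compound 3, `N#CC1=C(N)Oc2c(c3nc4ccccc4nc3c3ccccc23)C12C(=O)N(Cc1cnnn1-c1ccc(Br)cc1)c1ccccc12`, carries a 4-bromophenyl, and in this assay compound 3 gives 44300 nM, the only actual number among the three. The step of an at least 1.1-fold lower number from compound 1 to compound 3 (0.05 log units; that floor lies within the scatter) and the step of an at least 1.1-fold lower number from compound 2 to compound 3 (0.05 log units; that floor lies within the scatter) therefore have floors that lie within the scatter, and the step that the two limits leave unreadable from compound 1 to compound 2 cannot be read at all (the limit of > 50000 nM in this assay, at which 2 of the 3 values shown sit).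

Compound 4, `COc1ccccc1-n1nncc1CN1C(=O)C2(C(C#N)=C(N)Oc3c2c2nc4ccccc4nc2c2ccccc32)c2ccccc21`, differs from compound 3 in one place: 2-methoxyphenyl in place of 4-bromophenyl on an aromatic nitrogen. The steps measured so far give no sign of a change beyond the scatter, and the 2-methylphenyl relative, compound 1, sits at the limit, so for compound 4 the expected step is a 1.4-fold higher number from compound 3 to compound 4 (0.13 log units; within the scatter). Compound 4 is expected to give about 60000 nM, with a plausible span from 30000 nM to 150000 nM.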

Compound 4, half-maximal inhibitory concentration: > 50000 nM
Compound 4: no number, only a limit; the forecaster's own chance of this, stated with the estimate: 65%; the middle value does not contradict the limit.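

In this assay compound 4 gives > 50000 nM, which is a limit of the assay and not a number. Replacing the 4-bromophenyl with a 2-methoxyphenyl brings a hydrogen-bond acceptor to this place on the ring nitrogen, and the readable result is an at least 1.1-fold higher number from compound 3 to compound 4 (0.05 log units; that floor lies within the scatter), so this change shows no difference beyond the scatter. The steps from compound 1 and from compound 2 to compound 4 cannot be read, because both ends of each step are limits: the limit of > 50000 nM in this assay, at which 3 of the 4 values shown sit.

As far as these compounds go, whether any group at this place can give a number clearly lower than that of compound 3 remains open. From the compounds shown here alone, all four compounds carry a substituted phenyl here, so the effect of an amine or a carboxylic acid on that phenyl, or of a butyl chain in its place, remains unknown.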